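The source may report more compounds than this note shows. Statements on the series, on what has been measured and on what is new or still open speak of the compounds shown alone.

The compounds share one core and carry different amine groups on the chain bound to its aromatic oxygen. In a functional assay on SK-BR-3 cells (Homo sapiens) for antiproliferative activity (on this read-out lower numbers stand for stronger inhibition and higher numbers for weaker inhibition), compound 1 `CC(C)=CCc1cc(C(=O)Nc2cc3ccc(OCC4CCCNC4)c(C)c3oc2=O)ccc1O` gives 600 nM, compound 2 `CC(C)=CCc1cc(C(=O)Nc2cc3ccc(OCCCN(C)C(C)C)c(C)c3oc2=O)ccc1O` gives 570 nM and compound 3 `CC(C)=CCc1cc(C(=O)Nc2cc3ccc(OCCCNC(C)(C)C)c(C)c3oc2=O)ccc1O` gives 660 nM. Compound 3 therefore stands within the scatter of both other compounds. Compound 4 `CC(C)=CCc1cc(C(=O)Nc2cc3ccc(OCCCNc4ccccc4)c(C)c3oc2=O)ccc1O` is not yet measured and has phenyl in place of tert-butyl on an amine nitrogen.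

For the measured compounds named here, three measured steps bear on this change: a 1.1-fold lower number from compound 1 to compound 2 (0.02 log units; within the scatter), a 1.1-fold higher number from compound 1 to compound 3 (0.04 log units; within the scatter) and a 1.2-fold higher number from compound 2 to compound 3 (0.06 log units; within the scatter). Going by the values given here, all lie within the scatter, and the last is the closest precedent, as it also changes the substitution on the amine nitrogen. Among the compounds with values here, none of the measured compounds has an aromatic ring on that nitrogen, so the precedent is only partial. No step beyond the scatter is expected in this assay, and the estimated step is a 1.1-fold higher number from compound 3 to compound 4 (0.03 log units; within the scatter). Compound 4 is expected at 700 nM, with an estimated range of 300 nM to 1700 nM.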

Compound 4, half-maximal inhibitory concentration: > 50000 nM
Compound 4 was reported as a limit; the forecaster's own chance of this, stated with the estimate: 5%; at least 71-fold (1.85 log units) between middle value and limit.
By their numbers in this assay, from the lowest: compounds 2, 1 and 3 (each within the scatter of the next). At a limit, above all of these: compound 4.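

In this assay, the amine nitrogen on this chain turns out to be a sensitive place: compound 1, compound 2 and compound 3 lie within the scatter of one another, yet phenyl in place of tert-butyl gives an at least 75-fold higher number from compound 3 to compound 4 (1.87 log units; beyond the scatter). The other two comparisons agree, with anilino in place of isopropyl(methyl)amino giving an at least 87-fold higher number from compound 2 to compound 4 (1.94 log units; beyond the scatter) and 2-anilinoethyl in place of piperidin-3-yl giving an at least 83-fold higher number from compound 1 to compound 4 (1.92 log units; beyond the scatter), so the tolerance seen across the earlier amines does not extend to compound 4. Compound 4 is read only as a limit, not as a number: the limit of > 50000 nM in this assay, at which 1 of the 4 values shown sits.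

The compounds shown do not tell whether the loss goes with an aromatic ring directly on the nitrogen; a cyclohexyl or benzyl group there would test this. On these data alone, how far compound 4 lies past its limit also stays open.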